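Replacing the Isobutoxycarbonyl Cap on a Ring Nitrogen

The source may report more compounds than this note shows. Statements on the series, on what has been measured and on what is new or still open speak of the compounds shown alone.

Three measured compounds share a core in which a ring nitrogen carries a capping group and an attached aromatic part carries a side group. Compound 1 `CC(C)OC(=O)N1CCC(Oc2cccc3c2CCN3c2ccc(S(C)(=O)=O)cc2)CC1` is the weakest of them: in a functional assay on CHO-K1 cells for agonist activity at Glucose-dependent insulinotropic receptor (Homo sapiens), read by a luciferase reporter, with a stated time of 5 h (on this read-out higher numbers stand for an effect only at larger amounts of compound and lower numbers for an effect already at smaller amounts), compound 1 gives 501 nM. Compound 2 `CC(C)OC(=O)N1CCC(Oc2ncnc3c2CCN3c2ccc(C#N)cc2F)CC1` gives in this assay 63.1 nM. Compound 3 `CC(C)COC(=O)N1CCC(Oc2ncnc3c2CCN3c2ccc(S(C)(=O)=O)cc2F)CC1` gives 25.1 nM, the lowest of the three numbers; its gap to compound 2 and its far larger gap to compound 1 both lie beyond the usual scatter, so compound 3 is the most potent compound here.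

Compound 4 `CCS(=O)(=O)N1CCC(Oc2ncnc3c2CCN3c2ccc(S(C)(=O)=O)cc2F)CC1` differs from compound 3 in one place: ethylsulfonyl in place of isobutoxycarbonyl on an amine nitrogen in a ring. Within the data shown here, no measured pair shows this exchange, so its effect cannot be read off and can only be expected. Because compound 3 already gives 25.1 nM, the expectation starts from the lowest number seen. A cap of similar bulk replaces another on the same nitrogen, and such exchanges are often tolerated with some loss. The expected step is a 2.0-fold higher number from compound 3 to compound 4 (0.30 log units; within the scatter), a modest rise that may or may not exceed the scatter. Compound 4 is therefore estimated at 50 nM, within a range from 15 nM to 160 nM.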

Compound 4, half-maximal effective concentration: 1580 nM
Compound 4: the middle estimate sits 32-fold (1.50 log units) below what was measured; measured number outside the range, above it.
By their numbers in this assay, from the lowest: compound 3; then compound 2; then compound 1; then compound 4.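

The ring nitrogen is not indifferent to what caps it: in this assay, putting ethylsulfonyl in place of isobutoxycarbonyl brings a 63-fold higher number from compound 3 to compound 4 (1.80 log units; beyond the scatter), a large step well beyond the usual scatter. Among these compounds, this is the first direct reading of a change at this position, and it shows that two caps can match in hydrogen-bond donors, hydrogen-bond acceptors and net charge and still give very different numbers. Nothing available here explains why this exchange has so large an effect.

The exchange changes two things at once, the link to the ring nitrogen and the chain beyond it, so the compounds shown cannot separate the effect of the sulfonyl link from that of the smaller ethyl chain. Ethoxycarbonyl on the same nitrogen would pair the carbonyl link with the ethyl chain, and isobutylsulfonyl would pair the sulfonyl link with the isobutyl chain, so these two caps would show how much of the step belongs to each part.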